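Swapping a dibromoethenyl end for an ethynyl

This account rests on a few compounds, and the source may have more. Where it says the series, first, only, none or still open, it means among the compounds named here.

Compound 1 `CC(C)CC1C=C(Cl)CCO1`: > 100000 nM
Compound 2 `ClC1=CC(CCC=C(Br)Br)OCC1`: 16000 nM

In a functional assay on A2780 cells (Homo sapiens) for antiproliferative activity (on this read-out lower numbers stand for stronger inhibition of growth and higher numbers for weaker inhibition of growth), compound 1 reaches only a limit, > 100000 nM. In this assay, going by the values given here, compound 2 gives 16000 nM, the only real number here, the other entry being (the limit of > 100000 nM in this assay, at which 1 of the 2 values shown sits). Compound 3 `C#CCCC1C=C(Cl)CCO1` differs from compound 2 by ethynyl in place of 2,2-dibromoethenyl on a saturated chain carbon, two bonds along the chain from a saturated ring carbon. Among the compounds with values here, no measured step of this kind exists, so the expectation rests on these two values. Compound 1, whose chain end carries no halogen-bearing group, sits at the limit. With the halogens gone from compound 3 as well, a step beyond the scatter toward weaker growth inhibition is expected, a 3.1-fold higher number from compound 2 to compound 3 (0.49 log units; beyond the scatter). Compound 3 is estimated at 50000 nM, between 12000 nM and 200000 nM.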

Compound 3, concentration for 50% growth inhibition: 37000 nM
Compound 3: the middle estimate sits 1.4-fold (0.13 log units) above what was measured; the measured number falls inside the stated range.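

Losing both bromine atoms does not end growth inhibition in this assay: ethynyl in place of 2,2-dibromoethenyl gives a 2.3-fold higher number from compound 2 to compound 3 (0.36 log units; beyond the scatter). Compound 1 gives > 100000 nM, which is a limit of the assay. Propargyl in place of isopropyl gives an at least 2.7-fold lower number from compound 1 to compound 3 (0.43 log units; beyond the scatter), so a chain end without halogen can still give a real number, and the halogens are not required for a measurable effect.

As far as these compounds go, whether an amine, a nitrile or a longer chain at this chain end would give lower numbers remains open. So does whether a single bromine would be enough to match compound 2.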